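The source may report more compounds than this note shows. Statements on the series, on what has been measured and on what is new or still open speak of the compounds shown alone.

Working notes on the series.

Compound 1 `C=CCCOc1ncc(-c2ccccc2OC)n1C` and compound 2 `C=CCCCCOc1ncc(-c2ccccc2OC)n1C` share one core; compound 3 `C=CCCCCOc1ccccc1-c1cnc(S(=O)(=O)c2ccccc2)n1C` and compound 4 `C=CCCOc1ccccc1-c1cnc(S(=O)(=O)c2ccccc2)n1C` share another. The difference between the two cores is not broken down here.

In a functional assay on T98G cells (Homo sapiens) for inhibition, read by colorimetric assay and MTT assay, with a stated time of 72 h (on this read-out higher numbers stand for weaker inhibition and lower numbers for stronger inhibition), compound 2 gives 5000 nM, and compound 1 gives 39000 nM. The change between them is vinyl in place of but-3-en-1-yl on a saturated chain carbon, two bonds along the chain from an oxygen on an aromatic ring; the measured step is a 7.8-fold higher number from compound 2 to compound 1 (0.89 log units; beyond the scatter).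

In this assay compound 3 gives 71000 nM, the highest number of the three measured compounds; the gap to compound 1 lies within the scatter, and the gap to compound 2 lies beyond it.

Compound 4 carries the same change on the second core: vinyl in place of but-3-en-1-yl on a saturated chain carbon, two bonds along the chain from an oxygen on an aromatic ring. Among the compounds with values here, the only precedent for this change is the step from compound 2 to compound 1 on the first core, so the step in this assay is expected to go the same way, though its size may not carry over between cores: a 3.5-fold higher number from compound 3 to compound 4 (0.55 log units; beyond the scatter) is the expected step. Within the data shown here, for compound 4 the estimate in this assay is 250000 nM, with a range from 90000 nM to 700000 nM, resting on compound 2 to compound 1 as the single precedent.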

Compound 4, half-maximal inhibitory concentration: > 100000 nM
Compound 4 gave a limit, no number; the forecaster's own chance of this, stated with the estimate: 35%; the middle value does not contradict the limit.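

Compound 4 gives > 100000 nM in this assay, which is a limit of the assay and not a number. On the second core the change gives an at least 1.4-fold higher number from compound 3 to compound 4 (0.14 log units; that floor lies within the scatter), so the result agrees with the direction seen on the first core without confirming it, since that floor does not clear the scatter. What carries over between the two cores is therefore only the absence of a contradiction in direction, and nothing can be said yet about whether the size carries over: the same change on two cores in this assay, a 7.8-fold higher number (0.89 log units; beyond the scatter) from compound 2 to compound 1 and an at least 1.4-fold higher number (0.14 log units; that floor lies within the scatter) from compound 3 to compound 4; the limit leaves it open whether they differ

The compounds shown leave open how either core would respond to a chain longer than hex-5-en-1-yl, to a saturated chain of the same length, or to an amine in place of the chain. Also open, from the compounds shown here alone, is how far the true figure for compound 4 lies past the limit, and with it whether the change has the same size on both cores.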